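Chloro on the anilino ring of compound 2

The compounds below may be only part of what the source reports. "The series", "measured", "known", "first", "only" and "open" are said of these compounds alone.

Compound 2 `COc1ccc(C(=O)c2sc(Nc3ccccc3)c(C(=O)O)c2C)cc1` gives 24.7% in a functional assay, with a stated time of 150 min, tested at 10 ug/mL (on this read-out lower numbers stand for a weaker effect and higher numbers for a stronger effect at the one concentration tested), a number within the scatter of compound 1 `COC(=O)c1c(Nc2ccccc2)sc(C(=O)c2ccc(OC)cc2)c1C` at 18%. For the measured compounds named here, the only measured step, a number 6.7 percentage points higher from compound 1 to compound 2 (within the scatter), concerns the ester group and not the anilino ring. Compound 3 `COc1ccc(C(=O)c2sc(Nc3ccc(Cl)cc3)c(C(=O)O)c2C)cc1` differs from compound 2 by chloro in place of hydrogen on an aromatic carbon. Going by the values given here, no measured step bears on such a change, so no step beyond the scatter is expected. The estimated step is a number 2.3 percentage points higher from compound 2 to compound 3 (within the scatter). Compound 3 is therefore expected to give 27%, with a range from 10% to 50%.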

Compound 3, a percentage reported as activity, at one concentration (the size of the read-out at that concentration, not a potency): "not active" (no number reported)
The entry for compound 3 holds no number; there is nothing to compare the estimate with.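

For the compounds shown here, compound 3 is reported as "not active" without a number in this assay, so no step from compound 2 can be read, and no evidence bears on this entry. On these data alone, the size of any effect of 4-chlorophenyl over phenyl stays open.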